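A few compounds are considered here, and "the series" means these few. Any claim that something is new, unique, unknown or untested is made for them only; others in the source may bear on it.

Measured so far:
- compound 1, `C[C@@H](Oc1cc2oc(=O)n(CCC(=O)O)c2cc1Cl)c1ccc(F)cn1`, gives 25.1 nM in an assay on HEK293 cells for inhibition of kynurenine 3-monooxygenase (Homo sapiens), read by LC-MS, with a stated time of 20 h; a higher number here means a weaker inhibitor, a lower number a stronger inhibitor
- compound 2, `O=C(O)CCn1c(=O)oc2cc(OCC3CCC3)c(Cl)cc21`, gives 1260 nM in this assay

Compound 2 stands at the higher of the two numbers, so it is the weaker inhibitor of the pair; compound 1 sits far enough away that the gap is beyond the usual scatter of this assay, and no single-point step between the two is shown.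

Compound 3, `O=C(O)CCn1c(=O)oc2cc(OCc3ccccn3)c(Cl)cc21`, is made from compound 2 by one change: pyridin-2-yl in place of cyclobutyl on a saturated chain carbon bound to an oxygen on an aromatic ring. Compound 1 also carries a pyridin-2-yl ring, and its value in this assay is the lower one, so the change from compound 2 to compound 3 moves the structure in the direction of the stronger of the two measured compounds.

The step of an 8.4-fold lower number from compound 2 to compound 3 (0.92 log units; beyond the scatter) is expected to be a clear decrease, larger than the scatter, because compound 1 gives 25.1 nM. Compound 3 is therefore estimated at 150 nM, with a likely range from 40 nM to 600 nM; whether it reaches the level of compound 1 is uncertain, since compound 1 and compound 3 differ in more than this one place.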

Compound 3, half-maximal inhibitory concentration: 5010 nM
For compound 3 the middle estimate is 33-fold (1.52 log units) below the measured one; the whole stated range lies below it.
By their numbers in this assay, from the lowest: compound 1; then compound 2; then compound 3.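

In this assay, putting pyridin-2-yl in place of cyclobutyl on this saturated chain carbon bound to an oxygen on an aromatic ring brings a 4.0-fold higher number from compound 2 to compound 3 (0.60 log units; beyond the scatter), so compound 3 is the weaker inhibitor of this pair. At this position, then, an aromatic ring with one nitrogen does not lower the number on its own, and on the shared core the smaller carbon-only ring gives the better result of the two. Nothing in the data at hand explains this step.

Compound 1 also carries a pyridin-2-yl ring and gives 25.1 nM, yet it differs from compound 3 in more than one place, so the compounds shown cannot say which of its other features goes with that low number. From the compounds shown here alone, it also remains open whether the rise from cyclobutyl to pyridin-2-yl follows the ring nitrogen or the six-membered aromatic ring as a whole; a phenyl ring at the same place, which has the six-membered aromatic ring without the nitrogen, would separate these two readings.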